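The source may report more compounds than this note shows. Statements on the series, on what has been measured and on what is new or still open speak of the compounds shown alone.

Working notes on the permeability series. Compound 1 `N#Cc1ccccc1-c1cc(-c2cc(Cl)cc(OCCC(F)(F)F)c2)c(=O)n(-c2cccnc2)c1` gives 4 10^-6 cm/s in an ADME assay for permeability, using PAMPA, in phosphate buffer, with a stated time of 18 h, at pH 7.4; on this read-out higher numbers stand for higher permeability and lower numbers for lower permeability. Compound 2 `Cc1ncoc1COc1cc(Cl)cc(-c2cc(-c3c[nH]c(=O)[nH]c3=O)cn(-c3cccnc3)c2=O)c1` gives 0.24 10^-6 cm/s in this assay, the lowest of the two numbers seen so far and well separated from compound 1. Compound 3 `O=c1[nH]cc(-c2cc(-c3cc(Cl)cc(OCc4ocnc4C(F)(F)F)c3)c(=O)n(-c3cccnc3)c2)c(=O)[nH]1` is not yet measured in this assay; it differs from compound 2 by trifluoromethyl in place of methyl on an aromatic carbon. For the measured compounds named here, no measured pair shows this change, so the step is a guess: a small rise is expected, a 1.7-fold higher number from compound 2 to compound 3 (0.22 log units; within the scatter), probably within the scatter. For compound 3 the expected value in this assay is 0.4 10^-6 cm/s, with a range from 0.15 10^-6 cm/s to 1 10^-6 cm/s.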

Compound 3, apparent permeability: 0.57 10^-6 cm/s
The estimate for compound 3 lay 1.4-fold (0.15 log units) below the measured number; low and high end bracket the measured number.
By their numbers in this assay, from the lowest: compound 2; then compound 3; then compound 1.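

Trifluoromethyl in place of methyl, on the aromatic carbon next to the ring nitrogen of the five-membered ring, gives a 2.4-fold higher number from compound 2 to compound 3 (0.38 log units; beyond the scatter) in this assay as the first step in the series read at a single place. The number at this position therefore moves with this change, though only by a modest step. Nothing on hand accounts for that step.

On these data alone, whether an amine, a carboxylic acid or a longer chain on this carbon would move the number in the same direction stays open. Also open, as far as these compounds go, is whether the same change gives a similar step on another core.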